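The compounds below may be only part of what the source reports. "The series", "measured", "known", "first", "only" and "open" are said of these compounds alone.

Working notes on the series. In a functional assay on MCF7 cells (Homo sapiens) for antiproliferative activity, read by MTT assay, with a stated time of 72 h (on this read-out higher numbers stand for weaker inhibition and lower numbers for stronger inhibition), compound 1 (`CC(=O)NNC(=O)c1csc2ncc(-c3ccc(C)cc3)n12`) gives 57300 nM, compound 2 (`CCC(=O)NNC(=O)c1csc2ncc(-c3ccc(C)cc3)n12`) gives 5190 nM and compound 3 (`COc1ccc(-c2cnc3scc(C(=O)NNC(C)=O)n23)cc1`) gives 8360 nM. Compound 3 thus lies within the usual scatter of compound 2, and both sit well under compound 1.

Compound 4 (`CCC(=O)NNC(=O)c1csc2ncc(-c3ccc(OC)cc3)n12`) differs from compound 3 as follows: methyl in place of hydrogen on a saturated chain carbon bound to a carbonyl carbon. Acetyl becomes propanoyl. The same change gave a large step, an 11-fold lower number from compound 1 to compound 2 (1.04 log units; beyond the scatter). The methoxy for methyl change gave a modest one, a 6.9-fold lower number from compound 1 to compound 3 (0.84 log units; beyond the scatter). From the compounds shown here alone, whether the two steps add is untested, so a smaller step than the first, in the same direction, is expected in this assay. The expected step is a 4.2-fold lower number from compound 3 to compound 4 (0.62 log units; beyond the scatter). Compound 4 is estimated at 2000 nM, with an expected range of 600 nM to 6500 nM.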

Compound 4, half-maximal inhibitory concentration: 53200 nM
Beside the measured number, compound 4's estimate is 27-fold (1.42 log units) below it; the whole stated range lies below it.
By their numbers in this assay, from the lowest: compounds 2 and 3 (each within the scatter of the next); then compounds 4 and 1 (each within the scatter of the next).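

Acetyl to propanoyl has no fixed direction in this assay: with methoxy on the aromatic carbon it gives a 6.4-fold higher number from compound 3 to compound 4 (0.80 log units; beyond the scatter). Methoxy in place of methyl likewise turns against its earlier direction once the chain is propanoyl, with a 10-fold higher number from compound 2 to compound 4 (1.01 log units; beyond the scatter). The two changes therefore do not add, and the effect of each depends on the other: the same change on two cores in this assay, an 11-fold lower number (1.04 log units; beyond the scatter) from compound 1 to compound 2 and a 6.4-fold higher number (0.80 log units; beyond the scatter) from compound 3 to compound 4, 70-fold (1.85 log units) apart, beyond the scatter of two such steps

From the compounds shown here alone, it remains open whether a butanoyl chain would follow compound 2 or compound 4 on either aryl group. Also open, going by these compounds, is how a hydroxy group in place of the methoxy would behave with each chain.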